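A few compounds are considered here, and "the series" means these few. Any claim that something is new, unique, unknown or untested is made for them only; others in the source may bear on it.

Measured compounds:
compound 1 `O=c1[nH]c2ccccc2cc1/C=N/CCO` – in a functional assay, read by spectrophotometry, with a stated time of 1 h (a lower number here means a stronger inhibitor, a higher number a weaker inhibitor), compound 1 gives 3310000 nM
compound 2 `N/N=C/c1cc2ccccc2[nH]c1=O` – in this assay compound 2 gives 365000 nM
compound 3 `CCCC/N=C/c1cc2ccccc2[nH]c1=O` – in this assay compound 3 gives 7680000 nM

Compound 2 has the lowest number of the three, so it is the strongest inhibitor here. Compound 4 `O=c1[nH]c2ccccc2cc1/C=N/Nc1ccccc1` differs from compound 2 by phenyl in place of hydrogen on an amine nitrogen. Among the measured compounds shown here, no measured step changes this hydrogen; the two steps touching the same part of the molecule replace the whole amino group: a 9.1-fold lower number from compound 1 to compound 2 (0.96 log units; beyond the scatter) and a 21-fold higher number from compound 2 to compound 3 (1.32 log units; beyond the scatter). Both say that losing the amino group weakens inhibition, but compound 4 keeps it, so they give only an indirect hint. A modest weakening is expected, a 1.9-fold higher number from compound 2 to compound 4 (0.28 log units; within the scatter). Compound 4 is therefore estimated at 700000 nM, within a range of 150000 nM to 3000000 nM.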

Compound 4, half-maximal inhibitory concentration: 1000000 nM
Compound 4: middle estimate off by 1.4-fold (0.15 log units), on the low side, and the stated range covers the measured number.
By their numbers in this assay, from the lowest: compound 2; then compound 4; then compound 1; then compound 3.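

Among the compounds shown here, until now, every step at this end of the molecule replaced the whole amino group; this is the first to keep the amine nitrogen and change only its hydrogen. In this assay, phenyl in place of that hydrogen gives a 2.7-fold higher number from compound 2 to compound 4 (0.44 log units; beyond the scatter), so inhibition survives this addition, with a modest loss. No available evidence explains the size of this step.

The compounds shown leave open whether this loss is specific to phenyl or would also follow a smaller group on this nitrogen, such as methyl. As far as these compounds go, how a phenyl carrying chlorine or methoxy would compare also remains open.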